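The compounds below may be only part of what the source reports. "The series", "measured", "known", "first", "only" and "open" are said of these compounds alone.

In a functional assay on MOLT-4 cells (Homo sapiens) (a higher number here means a weaker inhibitor, a lower number a stronger inhibitor), compound 1, `COc1cc(NC(C)CCCNC(=O)NC(CO)(CO)CO)c2ncccc2c1`, gives > 100000 nM, which is a limit of the assay and not a number. Compound 2, `COc1cc(NC(C)CCCNC(=O)N(CCO)CCO)c2ncccc2c1`, gives > 100000 nM, which is also a limit. Compound 2 therefore has no numerical position, and the record so far is the limit of > 100000 nM in this assay, at which 2 of the 2 values shown sit.

Compound 3, `COC(=O)NCCCC(C)Nc1cc(OC)cc2cccnc12`, has not yet been measured. It carries methoxy in place of bis(2-hydroxyethyl)amino on a carbonyl carbon, so that bis(2-hydroxyethyl)carbamoyl becomes methoxycarbonyl: methoxy in place of bis(2-hydroxyethyl)amino on a carbonyl carbon.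

For the measured compounds named here, the only measured step that bears on this change is a step that the two limits leave unreadable from compound 1 to compound 2. It replaces one group on the same carbonyl carbon, but it gives no size to carry forward. The expectation is therefore loose: a modest move towards stronger inhibition in this assay, with a real chance that the assay again reports only a limit. The expected step is an at least 1.6-fold lower number from compound 2 to compound 3 (0.22 log units; that floor lies within the scatter), and this size is an estimate. For compound 3 the estimated value is 60000 nM, with an expected range of 15000 nM to 120000 nM.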

Compound 3, half-maximal inhibitory concentration: > 100000 nM
Compound 3 was reported as a limit; the forecaster's own chance of this, stated with the estimate: 50%; middle value at least 1.6-fold (0.22 log units) from the limit.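

In this assay compound 3 gives > 100000 nM, which is a limit of the assay and not a number. No step among compound 1, compound 2 and compound 3 can be read, and the record stays at a single limit: the limit of > 100000 nM in this assay, at which 3 of the 3 values shown sit.

The compounds shown leave open whether any group on this carbonyl carbon would give a measurable value in this assay.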